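The compounds below may be only part of what the source reports. "The series", "measured", "known", "first", "only" and "open" are said of these compounds alone.

Two compounds share one core and differ only in the group attached to the oxygen next to the carbonyl. Compound 1 `CCCCOC(=O)c1ccc(COC(COCc2ccc(OC)cc2)Cn2ccnc2)cc1` carries a butyl ester, and in an assay for inhibition of Thromboxane-A synthase (Homo sapiens), using microsomes (a lower number here means a stronger inhibitor, a higher number a weaker inhibitor), compound 1 gives 2000 nM. Compound 2 `COc1ccc(COCC(Cn2ccnc2)OCc2ccc(C(=O)OCc3ccccc3)cc2)cc1` carries a benzyl ester instead, and in this assay compound 2 gives 7100 nM. Going by the values given here, the move a 3.6-fold higher number from compound 1 to compound 2 (0.55 log units; beyond the scatter) is the only step measured so far, and it places compound 2 as the weaker of the two.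

Compound 3 `COc1ccc(COCC(Cn2ccnc2)OCc2ccc(C(=O)O)cc2)cc1` has not yet been measured. It differs from compound 2 by hydrogen in place of benzyl on an oxygen next to a carbonyl group, so the ester becomes a free carboxy group. Among the compounds with values here, no measured step covers the removal of the ester group itself; the step from compound 1 to compound 2 only shows that changing what sits on that oxygen shifts the number modestly. The expectation for compound 3 is therefore a number of similar order to that of compound 2, with the direction uncertain, amounting to an estimated step of a 2.4-fold lower number from compound 2 to compound 3 (0.37 log units; beyond the scatter). The estimate for compound 3 in this assay is 3000 nM, within a range of 600 nM to 15000 nM.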

Compound 3, half-maximal inhibitory concentration: 1100 nM
The estimate for compound 3 lay 2.7-fold (0.44 log units) above the measured number, and the stated range covers the measured number.
By their numbers in this assay, from the lowest: compounds 3 and 1 (each within the scatter of the next); then compound 2.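

Replacing benzyl with hydrogen on an oxygen next to a carbonyl group gives a 6.5-fold lower number from compound 2 to compound 3 (0.81 log units; beyond the scatter) in this assay, so the group on this oxygen can be removed entirely without losing inhibition. Replacing butyl with hydrogen at the same place gives a 1.8-fold lower number from compound 1 to compound 3 (0.26 log units; within the scatter), so the free carboxy compound and the butyl ester cannot be told apart, and among these three compounds only the benzyl ester, compound 2, stands apart as the weaker inhibitor. Nothing available here offers an explanation for these differences.

The compounds shown leave open how a methyl ester or a phenethyl ester would compare at this place. They also leave open how an amide in place of the carboxy group would read.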